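Shortening the chain on the ring nitrogen: compound 3 to 4

The source may hold more compounds than are shown below. What is called first, only, known or untested is meant among the compounds shown, and "the series" means these compounds.

Three compounds share a core that carries a hydroxamic acid and differ only in the group on a nitrogen attached to an aromatic ring. Compound 3 `CCCCCCCCN(Cc1ccc(C(=O)NO)cc1)c1ncc(-c2ccc(C)cc2)s1` gives 6500 nM in a functional assay on HCT-116 cells (Homo sapiens) for antiproliferative activity, read by MTT assay, with a stated time of 48 h; on this read-out higher numbers stand for weaker inhibition of growth and lower numbers for stronger inhibition of growth; compound 1 `Cc1ccc(OCCCN(Cc2ccc(C(=O)NO)cc2)c2ncc(-c3ccc(C)cc3)s2)cc1` gives 12600 nM, which lies within the usual scatter of compound 3, and compound 2 `CCCCCN(Cc1ccc(C(=O)NO)cc1)c1ncc(-c2ccc(C)cc2)s1` gives 23300 nM, separated by a 3.6-fold lower number from compound 2 to compound 3 (0.55 log units; beyond the scatter). Compound 4 `Cc1ccc(-c2cnc(N(Cc3ccc(C(=O)NO)cc3)C(C)C)s2)cc1` differs from compound 3 by isopropyl in place of octyl on a nitrogen on an aromatic ring. Going by the values given here, the only step that bears on it is the chain change from compound 2 to compound 3, where a longer chain gave a modestly lower number; compound 4 has a far shorter group, so a higher number is expected, a 4.6-fold higher number from compound 3 to compound 4 (0.66 log units; beyond the scatter). Compound 4 is therefore estimated at 30000 nM, ranging from 12000 nM to 80000 nM.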

Compound 4, concentration for 50% growth inhibition: 7800 nM
The estimate for compound 4 lay 3.8-fold (0.59 log units) above the measured number; the whole stated range lies above it.
By their numbers in this assay, from the lowest: compounds 3, 4, 1 and 2 (each within the scatter of the next, the first and the last beyond it).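

In this assay, this position on the nitrogen tolerates a large cut in the group: isopropyl matches octyl within the scatter (a 1.2-fold higher number from compound 3 to compound 4 (0.08 log units; within the scatter)), and it also matches 3-(4-methylphenoxy)propyl (a 1.6-fold lower number from compound 1 to compound 4 (0.21 log units; within the scatter)). Size therefore does not set the number in a single direction, and compound 2, with pentyl, goes against any such trend (a 3.0-fold lower number from compound 2 to compound 4 (0.48 log units; beyond the scatter)). No measurement available here explains why pentyl stands apart.

From the compounds shown here alone, whether an amine, a carboxylic acid or a chain longer than octyl on this nitrogen would move the number beyond the scatter of compound 3 remains open.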